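This account rests on a few compounds, and the source may have more. Where it says the series, first, only, none or still open, it means among the compounds named here.

Compound 1 `O=C(CN1CCN(C(=O)c2cccc(Cl)c2)CC1)N1CCN(CCCc2c[nH]c3ccccc23)CC1`: 99100 nM
Compound 2 `COc1cccc(C(=O)N2CCN(CC(=O)N3CCN(CCCc4c[nH]c5ccccc45)CC3)CC2)c1`: 143000 nM
Compound 3 `O=C(CN1CCN(C(=O)c2cccc(Br)c2)CC1)N1CCN(CCCc2c[nH]c3ccccc23)CC1`: 80700 nM

All three numbers come from an ADME assay on HEK293 cells (Homo sapiens) for cytotoxicity, read by MTT assay, with a stated time of 72 h; a lower number here means a stronger inhibitor, a higher number a weaker inhibitor. Compound 3 stands at 80700 nM, within the scatter of the other two compounds. The steps that reach it are a 1.2-fold lower number from compound 1 to compound 3 (0.09 log units; within the scatter) and a 1.8-fold lower number from compound 2 to compound 3 (0.25 log units; within the scatter). The remaining step, a 1.4-fold higher number from compound 1 to compound 2 (0.16 log units; within the scatter), also stays within the scatter, so these numbers give no firm ranking of the three compounds.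

The next compound, compound 4 `O=C(CN1CCN(C(=O)c2cccc(F)c2)CC1)N1CCN(CCCc2c[nH]c3ccccc23)CC1`, has not yet been measured. It differs from compound 3 by fluoro in place of bromo on an aromatic carbon, so that 3-bromophenyl becomes 3-fluorophenyl. Among the measured compounds shown here, no measured step involves fluoro, so the evidence is indirect. Chloro, bromo and methoxy have been exchanged at this same place, and the closest precedent, bromo in place of chloro, gave a 1.2-fold lower number from compound 1 to compound 3 (0.09 log units; within the scatter). On this evidence, no step beyond the scatter is expected in this assay. The expected step is a 1.3-fold higher number from compound 3 to compound 4 (0.11 log units; within the scatter), and its direction is only a weak expectation. For compound 4 the estimated value is 105000 nM, with an expected range from 65000 nM to 165000 nM.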

Compound 4, half-maximal inhibitory concentration: 182000 nM
Compound 4: middle estimate off by 1.7-fold (0.24 log units), on the low side; measured number outside the range, above it.
By their numbers in this assay, from the lowest: compounds 3, 1, 2 and 4 (each within the scatter of the next, the first and the last beyond it).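

In this assay, the exchange of bromo for fluoro on an aromatic carbon gives a 2.3-fold higher number from compound 3 to compound 4 (0.35 log units; beyond the scatter), a modest step and the first at this place to pass beyond the scatter, since the chloro, bromo and methoxy compounds had all stayed within it. Yet fluoro does not stand apart from the whole set, for a 1.8-fold higher number from compound 1 to compound 4 (0.26 log units; within the scatter) and a 1.3-fold higher number from compound 2 to compound 4 (0.10 log units; within the scatter) both remain within the scatter, so this position gives a readable difference only between compound 3 and compound 4, the two ends of the series. No measurement available here accounts for this difference between the bromo and fluoro compounds.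

The compounds shown leave open how this place on the ring responds to groups of another kind, such as an amine, a carboxylic acid or a nitrile, since all four carry a single halogen or a methoxy there. They also leave open whether a longer chain elsewhere in the shared core would shift the numbers in this assay, and whether the gap between compound 3 and compound 4 would persist with such a change.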